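This account rests on a few compounds, and the source may have more. Where it says the series, first, only, none or still open, it means among the compounds named here.

Compound 1 `O=C(CCCCCNC(=S)NN=C(c1ccccn1)c1ccccn1)NO`: 2870 nM
Compound 2 `O=C(CCCCCNC(=S)NN=C(c1ccccc1)c1ccccc1)NO`: 3810 nM
Compound 3 `C/C(=N\NC(=S)NCCCCCC(=O)NO)c1cccc(Br)c1`: 1260 nM

These numbers come from a functional assay on K562 cells (Homo sapiens) for antiproliferative activity, read by MTT assay; on this read-out lower numbers stand for stronger inhibition and higher numbers for weaker inhibition. Compound 2, at 3810 nM, lies within the usual scatter of compound 1, while compound 3 gives a lower number, beyond the scatter.

Compound 4 `COc1ccccc1/C(=N/NC(=S)NCCCCCC(=O)NO)c1ccccc1` is compound 2 with one alteration: methoxy in place of hydrogen on an aromatic carbon, a methoxy in place of hydrogen on an aromatic carbon. Within the data shown here, no measured pair shows this change alone. The structures of compound 2 and compound 1 differ, yet compound 1, at 2870 nM, stays within the scatter of compound 2. A step no larger than the scatter is therefore expected, with no firm direction. The estimated change is a 1.3-fold lower number from compound 2 to compound 4 (0.10 log units; within the scatter). Compound 4 is expected at 3000 nM, within an estimated range of 1300 nM to 7000 nM.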

Compound 4, half-maximal inhibitory concentration: 3560 nM
Beside the measured number, compound 4's estimate is 1.2-fold (0.07 log units) below it; measured number inside the range.
By their numbers in this assay, from the lowest: compound 3; then compounds 1, 4 and 2 (each within the scatter of the next).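

Putting a methoxy in place of hydrogen on an aromatic carbon, ortho to a large group, gives a 1.1-fold lower number from compound 2 to compound 4 (0.03 log units; within the scatter) in this assay. The two compounds therefore cannot be told apart on this read-out, so this position accepts the added methoxy without a step beyond the scatter. Nothing measured here addresses what lies behind this result.

From the compounds shown here alone, whether an amine or a carboxylic acid at the same position would also stay within the scatter remains open. So does the outcome for a methoxy placed elsewhere on this ring.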